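The source may hold more compounds than are shown below. What is called first, only, known or untested is meant among the compounds shown, and "the series" means these compounds.

Working notes, series on the shared core.

Compound 1 `OC[C@H]1C[C@@H](Cn2cnc3c(-c4ccc(Cl)cc4)ncnc32)c2ccccc21` carries a 4-chlorophenyl on the core and in a functional assay on MOLT-4 cells (Homo sapiens) (a higher number here means a weaker inhibitor, a lower number a stronger inhibitor), compound 1 gives 0.63 ug/mL. Compound 2 `OC[C@H]1C[C@@H](Cn2cnc3c(O)ncnc32)c2ccccc21` has a hydroxy at that carbon instead, and in this assay compound 2 gives 24 ug/mL. Compound 3 `COc1ncnc2c1ncn2C[C@@H]1C[C@H](CO)c2ccccc21` has a methoxy there; in this assay compound 3 gives 24 ug/mL, which puts compound 3 level with compound 2 at the digits shown and together with compound 2 at the weak end of the three numbers, with the change no change at the digits printed from compound 2 to compound 3 (within the scatter). The two large steps recorded, a 38-fold higher number from compound 1 to compound 2 (1.58 log units; beyond the scatter) and a 38-fold higher number from compound 1 to compound 3 (1.58 log units; beyond the scatter), show that leaving the 4-chlorophenyl for either oxygen substituent costs a great deal.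

Compound 4 `OC[C@H]1C[C@@H](Cn2cnc3c(Cl)ncnc32)c2ccccc21` is not yet measured. The change from compound 3 is chloro in place of methoxy on an aromatic carbon. Among the compounds with values here, no measured step involves a chloro at this carbon, so the closest guides are the two oxygen substituents, which gave identical numbers. A chloro is neither of those nor the 4-chlorophenyl, so a step of modest size toward compound 1 at most is expected, not beyond the scatter with confidence: a 1.6-fold lower number from compound 3 to compound 4 (0.20 log units; within the scatter). For compound 4 in this assay a value near 15 ug/mL is estimated, expected to fall between 4 ug/mL and 40 ug/mL.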

Compound 4, half-maximal inhibitory concentration: 24 ug/mL
For compound 4 the middle estimate is 1.6-fold (0.20 log units) below the measured one; measured number inside the range.
By their numbers in this assay, from the lowest: compound 1; then compounds 2, 3 and 4 (each within the scatter of the next).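

In this assay, chloro in place of methoxy gives no change at the digits printed from compound 3 to compound 4 (within the scatter), and chloro in place of hydroxy gives no change at the digits printed from compound 2 to compound 4 (within the scatter), so hydroxy, methoxy and chloro on this aromatic carbon are not told apart by this read-out. The third step, a 38-fold higher number from compound 1 to compound 4 (1.58 log units; beyond the scatter), shows that a chloro placed directly on this carbon does not reproduce the value of compound 1, so among the compounds shown, the low number goes only with the complete 4-chlorophenyl group. Nothing measured here accounts for the level values of compounds 2, 3 and 4 or for their gap to compound 1.

The compounds shown leave open whether the low number needs the chlorine of the 4-chlorophenyl group at all, a question that an unsubstituted phenyl at this carbon would address. They also leave open how an amine or a longer alkyl chain at this carbon would compare with the three small substituents and with the 4-chlorophenyl group.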